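Swapping Benzoyl for 4-Fluorobenzyl on an Aromatic Nitrogen

The source may hold more compounds than are shown below. What is called first, only, known or untested is meant among the compounds shown, and "the series" means these compounds.

Among the compounds with values here, compound 2 `O=C1COCCN1c1ccc(/N=C\c2cn(C(=O)c3ccccc3)c3ccccc23)cc1` carries a benzoyl on an aromatic nitrogen of the shared core; in an ADME assay on BV-2 cells (Mus musculus) for cytotoxicity, read by MTT assay, with a stated time of 48 h, tested at 5 uM (a higher number here means a weaker effect of the compound at the concentration tested, a lower number a stronger effect), compound 2 gives 87.3%, the lower of the two numbers measured so far. Compound 1 `O=C1COCCN1c1ccc(/N=C\c2c[nH]c3ccccc23)cc1` bears hydrogen there and in this assay compound 1 gives 101%. Within the data shown here, the only measured step is a number 13.7 percentage points lower from compound 1 to compound 2 (beyond the scatter). Compound 3 `O=C1COCCN1c1ccc(/N=C\c2cn(Cc3ccc(F)cc3)c3ccccc23)cc1` differs from compound 2 by 4-fluorobenzyl in place of benzoyl on an aromatic nitrogen. Among the measured compounds shown here, no measured step covers this change, so the step from compound 2 to compound 3 is expected to stay small, at a number 1.7 percentage points higher from compound 2 to compound 3 (within the scatter). Compound 3 is estimated at 89%, between 74% and 102%.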

Compound 3, a percentage reported as activity, at one concentration (the size of the read-out at that concentration, not a potency): 69.3%
Beside the measured number, compound 3's estimate is 19.7 percentage points above it, and the stated range ends above it.
By their numbers in this assay, from the lowest: compound 3; then compound 2; then compound 1.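

At this aromatic nitrogen, the identity of the added group matters, not just the presence of a ring: this assay shows a number 18 percentage points lower from compound 2 to compound 3 (beyond the scatter) even though benzoyl and 4-fluorobenzyl each carry one six-membered aromatic ring of carbon only. Measured against hydrogen, 4-fluorobenzyl gives a number 31.7 percentage points lower from compound 1 to compound 3 (beyond the scatter) as the largest step yet seen at this position. Nothing available explains the gap between the two groups. Still open, as far as these compounds go, is how a plain benzyl without the fluorine would compare, and whether a longer chain ending in an amine or a carboxylic acid would push the number lower or raise it.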